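Swapping Amino for Iodo on the Aryl Ring

A few compounds are considered here, and "the series" means these few. Any claim that something is new, unique, unknown or untested is made for them only; others in the source may bear on it.

Of the compounds shown here, three sharing one core have been tested in a functional assay (muscle tissue) with Cavia porcellus as the target; on this read-out higher numbers stand for an effect only at larger amounts of compound and lower numbers for an effect already at smaller amounts. Compound 1 `COC(=O)C1=C(C)N=C(C)/C(=C(\O)OC)C1c1ccc(F)cc1` gives 129 nM and compound 3 `COC(=O)C1=C(C)N=C(C)/C(=C(\O)OC)C1c1cc(C)ccc1C` gives 100 nM, while compound 2 `COC(=O)C1=C(C)N=C(C)/C(=C(\O)OC)C1c1cccc(N)c1` gives 2000 nM, the highest number of the three. The steps of a 16-fold higher number from compound 1 to compound 2 (1.19 log units; beyond the scatter) and a 20-fold lower number from compound 2 to compound 3 (1.30 log units; beyond the scatter) set compound 2 far apart from the other two, whereas a 1.3-fold lower number from compound 1 to compound 3 (0.11 log units; within the scatter). Compound 4 `COC(=O)C1=C(C)N=C(C)/C(=C(\O)OC)C1c1cccc(I)c1` differs from compound 2 by iodo in place of amino on an aromatic carbon. Both large steps involved the amino group entering or leaving, and the present change also removes it, so a large drop is expected; because a 20-fold lower number from compound 2 to compound 3 (1.30 log units; beyond the scatter) was large, the expected step is a 20-fold lower number from compound 2 to compound 4 (1.30 log units; beyond the scatter). The estimate for compound 4 is therefore 100 nM, with a range from 20 nM to 500 nM.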

Compound 4, half-maximal effective concentration: 41.7 nM
Compound 4: middle estimate off by 2.4-fold (0.38 log units), on the high side, within the range that was stated.
By their numbers in this assay, from the lowest: compound 4; then compounds 3 and 1 (each within the scatter of the next); then compound 2.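

Among the compounds shown here, compound 2 and compound 4 are the first pair here that differ at a single aromatic carbon, and in this assay that one swap gives a 48-fold lower number from compound 2 to compound 4 (1.68 log units; beyond the scatter). The iodo compound also moves past the two earlier low values, with a 2.4-fold lower number from compound 3 to compound 4 (0.38 log units; beyond the scatter) and a 3.1-fold lower number from compound 1 to compound 4 (0.49 log units; beyond the scatter), which leaves it with the lowest number of the four. Nothing at hand explains why this swap has such an effect. Going by these compounds, it remains open how bromo, nitro or methoxy on the same aromatic carbon would compare. Also open, on these data alone, is whether a plain phenyl ring would fall nearer compound 2 or compound 4.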